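The compounds below may be only part of what the source reports. "The series", "measured", "known", "first", "only" and "open" are said of these compounds alone.

In a functional assay on Jurkat cells (Homo sapiens) for antiproliferative activity, read by MTT assay, with a stated time of 72 h (a lower number here means a stronger inhibitor, a higher number a weaker inhibitor), compound 1 `COc1cc(-n2ncnc2-c2ccc(OC(F)(F)F)cc2)cc(OC)c1OC` gives > 10000 nM, which is a limit of the assay and not a number. Compound 2 `COc1cc(-n2ncnc2-c2cccc([N+](=O)[O-])c2)cc(OC)c1OC` gives > 10000 nM, and this too is a limit. Together these results amount to the limit of > 10000 nM in this assay, at which 2 of the 2 values shown sit. Going by the values given here, compound 1 therefore has no measured potency to serve as a starting point, and no step between measured compounds is available as a guide.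

The next compound, compound 3 `COc1cc(-n2ncnc2-c2ccc(SC)cc2)cc(OC)c1OC`, keeps the core of compound 1 and changes one substituent. Methylsulfanyl replaces trifluoromethoxy on an aromatic carbon, para to a large group: methylsulfanyl in place of trifluoromethoxy on an aromatic carbon. With nothing but limits to go on, only a modest and uncertain gain is expected in this assay, toward a stronger inhibitor. The estimated step is an at least 3.3-fold lower number from compound 1 to compound 3 (0.52 log units; beyond the scatter), and it could prove smaller, since a further limit reading remains quite possible. The estimated value for compound 3 is 3000 nM, with an expected range from 100 nM to 15000 nM.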

Compound 3, half-maximal inhibitory concentration: 50 nM
The estimate for compound 3 lay 60-fold (1.78 log units) above the measured number; measured number outside the range, below it.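

With methylsulfanyl in place of trifluoromethoxy, on an aromatic carbon para to a large group, this assay shows an at least 200-fold lower number from compound 1 to compound 3 (2.30 log units; beyond the scatter), so a change at this one place is enough to take the shared core from a limit reading to a measured number. Compound 1 gives > 10000 nM, which is a limit of the assay and not a number, so the step marks only the smallest possible size of the true gap. Compound 3 is the only compound shown that carries a measured number, and the others remain at the limit: the limit of > 10000 nM in this assay, at which 2 of the 3 values shown sit.

The compounds shown leave open whether the sulfur atom matters here, or whether the change depends instead on the loss of the oxygen and fluorine atoms of trifluoromethoxy, since this single pair changes all of these at once. From the compounds shown here alone, a methoxy group, an ethylsulfanyl chain or a methylsulfonyl group at this same place would help to separate these readings, and it also remains open how far a longer chain could go before the number returns to the limit.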